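This account rests on a few compounds, and the source may have more. Where it says the series, first, only, none or still open, it means among the compounds named here.

Compound 3 `COc1cc(Cl)cc(-c2nn(-c3cccc(NC(=O)Nc4cc(C(F)(F)F)cc(C(F)(F)F)c4)c3)cc2-c2ccncc2)c1` gives 8.99% in a functional assay on CAKI-1 cells (Homo sapiens) for inhibition, read by sulforhodamine B assay, with a stated time of 48 h, tested at 10 uM (on this read-out lower numbers stand for a stronger effect and higher numbers for a weaker effect at the one concentration tested), the lowest of the three numbers recorded. Compound 2 `COc1cc(Cl)cc(-c2nn(-c3cccc(NC(=O)Nc4ccc(Cl)c(C(F)(F)F)c4)c3)cc2-c2ccncc2)c1` gives 9.38%, which lies within the scatter of the value of compound 3, while compound 1 `O=C(Nc1cccc(-n2cc(-c3ccncc3)c(-c3cc(O)cc(Cl)c3)n2)c1)Nc1ccc(Cl)c(C(F)(F)F)c1` gives 29.1%, beyond the scatter. Within the data shown here, the one measured step, a number 19.7 percentage points lower from compound 1 to compound 2 (beyond the scatter), concerns a different part of the shared core and so bears only loosely on the change to compound 4 `COc1cc(Cl)cc(-c2nn(-c3cccc(NC(=O)Nc4cccc(C(F)(F)F)c4)c3)cc2-c2ccncc2)c1`, which is hydrogen in place of trifluoromethyl on an aromatic carbon. Compounds 2 and 3 differ elsewhere and still give values within the scatter of each other, suggesting some tolerance there. Compound 4 is therefore expected to change little, a number 6 percentage points higher from compound 3 to compound 4 (within the scatter), estimated at 15% in this assay, between 5% and 35%.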

Compound 4, a percentage reported as activity, at one concentration (the size of the read-out at that concentration, not a potency): 16.1%
The estimate for compound 4 lay 1.1 percentage points below the measured number; the range from low to high includes it.
By their numbers in this assay, from the lowest: compounds 3, 2 and 4 (each within the scatter of the next); then compound 1.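

In this assay, hydrogen in place of trifluoromethyl gives a number 7.1 percentage points higher from compound 3 to compound 4 (within the scatter), and hydrogen in place of chloro gives a number 6.7 percentage points higher from compound 2 to compound 4 (within the scatter). Compounds 2 and 3 had shown only that two substituted forms gave close values, whereas compound 4 shows that this aromatic carbon can carry plain hydrogen without a change beyond the scatter. No measurement shown here offers an explanation for this tolerance. Going by these compounds, whether an amine or a carboxylic acid on this carbon would remain as tolerated stays open. So does whether the remaining trifluoromethyl group can be replaced by hydrogen as well.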